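Anilinoquinazoline thioethers against prostate cancer cells: a fourth analogue

This account rests on a few compounds, and the source may have more. Where it says the series, first, only, none or still open, it means among the compounds named here.

Compound 1 `FC(F)(F)c1ccc(CSc2nc(Nc3ccccc3C(F)(F)F)c3ccccc3n2)cc1`: 34800 nM
Compound 2 `CCOc1ccccc1Nc1nc(SCc2ccc(C(F)(F)F)cc2)nc2ccccc12`: 26200 nM
Compound 3 `Cc1ccccc1Nc1nc(SCc2ccc(C(F)(F)F)cc2)nc2ccccc12`: 36900 nM

In a functional assay on PC-3 cells (Homo sapiens) for cytotoxicity, read by MTT assay, with a stated time of 72 h (on this read-out higher numbers stand for weaker inhibition and lower numbers for stronger inhibition), compound 3 gives the highest of the three numbers, yet both steps that reach it, a 1.1-fold higher number from compound 1 to compound 3 (0.03 log units; within the scatter) and a 1.4-fold higher number from compound 2 to compound 3 (0.15 log units; within the scatter), lie within the scatter, so the three compounds cannot be told apart. Compound 4 `COc1ccc(Nc2nc(SCc3ccc(C(F)(F)F)cc3)nc3ccccc23)c(OC)c1` brings the change (2,4-dimethoxyphenyl in place of 2-methylphenyl on a nitrogen on an aromatic ring). Within the data shown here, no measured step covers this exact change; the nearest guide is that swapping trifluoromethyl, ethoxy and methyl on the same aromatic carbon moved nothing beyond the scatter, as a 1.3-fold lower number from compound 1 to compound 2 (0.12 log units; within the scatter) shows. Compound 4 is therefore expected to sit close to compound 3, with a step of a 1.2-fold lower number from compound 3 to compound 4 (0.09 log units; within the scatter), giving an estimate of 30000 nM within 12000 nM to 75000 nM.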

Compound 4, half-maximal inhibitory concentration: 32500 nM
Beside the measured number, compound 4's estimate is 1.1-fold (0.03 log units) below it; the range from low to high includes it.
By their numbers in this assay, from the lowest: compounds 2, 4, 1 and 3 (each within the scatter of the next).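

In this assay, the ring on this nitrogen now carries two methoxy groups rather than a single group, yet all three new steps stay within the scatter: a 1.1-fold lower number from compound 3 to compound 4 (0.06 log units; within the scatter), a 1.2-fold higher number from compound 2 to compound 4 (0.09 log units; within the scatter) and a 1.1-fold lower number from compound 1 to compound 4 (0.03 log units; within the scatter). Across the four compounds shown, then, this larger change at this position moves the number no more than the single-group swaps did. No available evidence explains this result. The compounds shown leave open whether an amine or a carboxylic acid on this ring would give a step beyond the scatter.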